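Amide substituent and core substituent changes in a chemokine series

The source may hold more compounds than are shown below. What is called first, only, known or untested is meant among the compounds shown, and "the series" means these compounds.

Values in an in vitro assay on BaF3 cells for displacement of a labelled ligand from C-X-C chemokine receptor type 3 (Homo sapiens); a lower number here means a stronger inhibitor, a higher number a weaker inhibitor:
compound 1 `CC[C@H]1CN(c2ncc(C(=O)NC3CC3)nc2Cl)CCN1C1CCN(C(=O)c2ccc(Cl)nc2N)CC1`: 1.2 nM
compound 2 `CC[C@H]1CN(c2ncc(C(=O)NC(C)C)nc2Cl)CCN1C1CCN(C(=O)c2ccc(Cl)nc2N)CC1`: 0.9 nM
compound 3 `CC[C@H]1CN(c2ncc(C(=O)NCCO)nc2Cl)CCN1C1CCN(C(=O)c2ccc(Cl)nc2N)CC1`: 2.9 nM

Compound 1 stands second highest of the three numbers. Its nearest neighbour is compound 2, with a 1.3-fold lower number from compound 1 to compound 2 (0.12 log units; within the scatter); the two are not separable. Its furthest is compound 3, with a 2.4-fold higher number from compound 1 to compound 3 (0.38 log units; beyond the scatter), and the related step of a 3.2-fold higher number from compound 2 to compound 3 (0.51 log units; beyond the scatter) points the same way. Every measured step alters only the group on the amide-type nitrogen; the core carries chloro in all three.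

Compound 4 `CC[C@H]1CN(c2ncc(C(=O)NC3CC3)nc2C)CCN1C1CCN(C(=O)c2ccc(Cl)nc2N)CC1` differs from compound 1 by methyl in place of chloro on an aromatic carbon. Among the measured compounds shown here, no measured step touches this position, so the three amide steps give no direct guide; they show only that the series tolerates small changes with modest movement. The expectation is therefore a step near zero, a 1.5-fold higher number from compound 1 to compound 4 (0.18 log units; within the scatter), with no clear direction beyond the scatter. Compound 4 is estimated at 1.8 nM, in the range 0.6 nM to 5.5 nM.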

Compound 4, half-maximal inhibitory concentration: 1.9 nM
For compound 4 the middle estimate is 1.1-fold (0.02 log units) below the measured one, and the stated range covers the measured number.
By their numbers in this assay, from the lowest: compounds 2, 1, 4 and 3 (each within the scatter of the next, the first and the last beyond it).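

In this assay, methyl in place of chloro on the aromatic carbon next to the ring nitrogen gives a step that cannot be separated from the scatter (a 1.6-fold higher number from compound 1 to compound 4 (0.20 log units; within the scatter)). The position, untouched by the amide steps, therefore accepts methyl as well as chloro, and a chloro there is not required for a low number, at least alongside the cyclopropylcarbamoyl group shared by compound 1 and compound 4. No measured information accounts for how closely the two groups read.

Open, on these data alone, is whether this position also accepts a methoxy group, a nitrile or an amine. Also open, as far as these compounds go, is whether the methyl result carries over to the isopropyl and 2-hydroxyethyl amides of compound 2 and compound 3.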